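The source may hold more compounds than are shown below. What is called first, only, known or untested is meant among the compounds shown, and "the series" means these compounds.

In an in vitro ADME assay on microsomes from liver (Mus musculus) for pharmacokinetics, read by LC-MS, with a stated time of 10 min, tested at 1 uM (a lower number here means slower removal, a higher number faster removal of the compound), compound 1 (`CN1C[C@H](C(=O)Nc2ccccc2)[C@@H](c2ccc(/C=C/C(=O)Nc3ccccc3N)cc2)C1`) gives 67 mL/min/kg, compound 2 (`CN1C[C@H](C(=O)Nc2ccc(F)c(Cl)c2)[C@@H](c2ccc(/C=C/C(=O)Nc3ccccc3N)cc2)C1`) gives 34 mL/min/kg and compound 3 (`CN1C[C@H](C(=O)Nc2ccc(F)c(Br)c2)[C@@H](c2ccc(/C=C/C(=O)Nc3ccccc3N)cc2)C1`) gives 43 mL/min/kg. Compound 3 therefore stands within the scatter of both other compounds, as a 1.6-fold lower number from compound 1 to compound 3 (0.19 log units; within the scatter) and a 1.3-fold higher number from compound 2 to compound 3 (0.10 log units; within the scatter) show. Compound 4 (`CN1C[C@H](C(=O)Nc2ccc(Cl)c(Cl)c2)[C@@H](c2ccc(/C=C/C(=O)Nc3ccccc3N)cc2)C1`) has 3,4-dichlorophenyl in place of 3-bromo-4-fluorophenyl on an amide-type nitrogen. The closest measured evidence is a 1.3-fold higher number from compound 2 to compound 3 (0.10 log units; within the scatter), which swaps chloro and bromo on an aromatic carbon and stays within the scatter. The wider changes, a 2.0-fold lower number from compound 1 to compound 2 (0.29 log units; within the scatter) and a 1.6-fold lower number from compound 1 to compound 3 (0.19 log units; within the scatter), also stay within it. Among the compounds with values here, no measured step shows chloro replacing fluoro, so that part of the change remains untested and the range must stay wide. No shift beyond the scatter is expected in this assay, and the expected step is a 1.1-fold lower number from compound 3 to compound 4 (0.03 log units; within the scatter). For compound 4 the estimated clearance is 40 mL/min/kg, with an expected range of 20 mL/min/kg to 80 mL/min/kg.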

Compound 4, clearance: 36 mL/min/kg
Compound 4: middle estimate off by 1.1-fold (0.05 log units), on the high side; the range from low to high includes it.
By their numbers in this assay, from the lowest: compounds 2, 4, 3 and 1 (each within the scatter of the next).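

In this assay, within the data shown here, the step of a 1.1-fold higher number from compound 2 to compound 4 (0.02 log units; within the scatter) gives the first reading of chloro in place of fluoro on an aromatic carbon, and it stays within the scatter, as do the direct change a 1.2-fold lower number from compound 3 to compound 4 (0.08 log units; within the scatter) and the wider change a 1.9-fold lower number from compound 1 to compound 4 (0.27 log units; within the scatter). Phenyl, 3-chloro-4-fluorophenyl, 3-bromo-4-fluorophenyl and 3,4-dichlorophenyl on the amide-type nitrogen therefore cannot be told apart by clearance in this assay, since every step among them lies within the scatter. Nothing available explains why these steps are so small.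

On these data alone, only phenyl and its halogenated forms appear at this position, so it remains open whether a nitrile, a methoxy group or a carboxylic acid on that ring, or a morpholine in its place, would move clearance beyond the scatter. As far as these compounds go, it also remains open whether any change elsewhere on the shared core would do so.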